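This account rests on a few compounds, and the source may have more. Where it says the series, first, only, none or still open, it means among the compounds named here.

The measured compounds:

- Compound 1, `COc1cccc2c1c(C(=O)/C=C(\O)C(=O)O)cn2Cc1ccccc1F`: 70500 nM
- Compound 2, `CCOC(=O)/C(O)=C/C(=O)c1cn(Cc2ccccc2F)c2cccc(OC)c12`: 63300 nM
- Compound 3, `CCOC(=O)/C(O)=C/C(=O)c1cn(Cc2c(F)ccc(F)c2F)c2cccc(OC)c12`: 40500 nM

All three were tested in an ADME assay on MT4 cells (Homo sapiens) for cytotoxicity, read by MTT assay; on this read-out higher numbers stand for lower toxicity in this test and lower numbers for higher toxicity in this test. Compound 1 gives 70500 nM, compound 2 gives 63300 nM, and compound 3 gives 40500 nM. Compound 2 and compound 1 share one core and differ only in the change (hydrogen in place of ethyl on an oxygen next to a carbonyl group); the step of a 1.1-fold higher number from compound 2 to compound 1 (0.05 log units; within the scatter). Compound 2 and compound 3 differ in the change (2,3,6-trifluorophenyl in place of 2-fluorophenyl on a saturated chain carbon bound to an aromatic nitrogen); here the step of a 1.6-fold lower number from compound 2 to compound 3 (0.19 log units; within the scatter). Compound 3 thus has the lowest of the three numbers, but every gap among them lies within the scatter, so none of the three can be set apart from the others in this assay .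

Compound 4, `COc1cccc2c1c(C(=O)/C=C(\O)C(=O)O)cn2Cc1c(F)ccc(F)c1F`, has not yet been measured. It differs from compound 3 by hydrogen in place of ethyl on an oxygen next to a carbonyl group. For the measured compounds named here, this is the same change, at the same place, as the one from compound 2 to compound 1, so the step already seen gives the best guide. The expected step is a 1.1-fold higher number from compound 3 to compound 4 (0.05 log units; within the scatter), and this expectation rests on the measured step of a 1.1-fold higher number from compound 2 to compound 1 (0.05 log units; within the scatter), which stayed within the scatter. Compound 4 is therefore estimated at 45000 nM in this assay , with a likely range from 20000 nM to 95000 nM.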

Compound 4, half-maximal cytotoxic concentration: 49400 nM
The estimate for compound 4 lay 1.1-fold (0.04 log units) below the measured number, and the stated range covers the measured number.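

Swapping ethyl for hydrogen, which turns the ethoxycarbonyl group into a carboxy group, gives a 1.2-fold higher number from compound 3 to compound 4 (0.09 log units; within the scatter) in this assay, and this agrees with the same change on the other core: the same change on two cores in this assay, a 1.1-fold higher number (0.05 log units; within the scatter) from compound 2 to compound 1 and a 1.2-fold higher number (0.09 log units; within the scatter) from compound 3 to compound 4, 1.1-fold (0.04 log units) apart, within the scatter of two such steps. Putting 2,3,6-trifluorophenyl in place of 2-fluorophenyl, now read on the two carboxy compounds, gives a 1.4-fold lower number from compound 1 to compound 4 (0.15 log units; within the scatter), and this too agrees with the step seen before: the same change on two cores in this assay, a 1.6-fold lower number (0.19 log units; within the scatter) from compound 2 to compound 3 and a 1.4-fold lower number (0.15 log units; within the scatter) from compound 1 to compound 4, 1.1-fold (0.04 log units) apart, within the scatter of two such steps. For the compounds shown here, every one of these steps lies within the scatter, so the two pairs show only that neither change moved the number measurably on these cores; they do not show that a real effect of fixed size carries from one core to another, and two pairs set no rule for a wider series.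

What the compounds shown leave open is whether another group in place of the ethyl on an oxygen next to a carbonyl group, such as methyl or a longer chain, would behave in the same way. As far as these compounds go, it also remains open whether a phenyl ring carrying chlorine or methoxy instead of fluorine would give a step beyond the scatter in this assay.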